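The source may report more compounds than this note shows. Statements on the series, on what has been measured and on what is new or still open speak of the compounds shown alone.

Measured so far:
- compound 1, `Brc1cncc(N2CC[C@@H]3CN[C@@H]3C2)c1`: in a functional assay on HEK293 cells for agonist activity at Neuronal acetylcholine receptor; alpha4/beta2 (Homo sapiens), read by FLIPR (on this read-out higher numbers stand for an effect only at larger amounts of compound and lower numbers for an effect already at smaller amounts), compound 1 gives 1000 nM
- compound 2, `N#Cc1cncc(N2CC[C@H]3CN[C@H]3C2)c1`: in this assay compound 2 gives 1900 nM

Compound 2 has the highest of the two numbers in this assay; its nearest neighbour is compound 1, and the gap between the two values lies within the scatter, so the two compounds cannot be told apart on these numbers.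

Compound 3, `N#Cc1cncc(N2CC[C@@H]3CN[C@@H]3C2)c1`, is not yet measured. It differs from compound 2 as follows: the two compounds have the same atoms and bonds and differ only in configuration as drawn: 2 of 2 stereo elements differ (all stereocentres are inverted: mirror images); a stereocentre at a saturated ring carbon is drawn S in compound 2 and R in compound 3; a stereocentre at a saturated ring carbon is drawn R in compound 2 and S in compound 3. Among the compounds with values here, no step between two measured compounds is available to anchor the size of such a change, so the direction of the step from compound 2 to compound 3 is open. Inverting both stereocentres may leave the number near that of compound 2, or move it well beyond the scatter in either direction. With that caution, compound 3 is expected to give 1200 nM in this assay, in the range 250 nM to 6000 nM, which would mean an estimated step of a 1.6-fold lower number from compound 2 to compound 3 (0.20 log units; within the scatter).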

Compound 3, half-maximal effective concentration: 1900 nM
Estimate against measurement, compound 3: 1.6-fold (0.20 log units) below, within the range that was stated.
By their numbers in this assay, from the lowest: compounds 1, 2 and 3 (each within the scatter of the next).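

In this assay, the mirror-image pair gives no change at the digits printed from compound 2 to compound 3 (within the scatter), so inverting both stereocentres on the cyano-bearing core produces no difference that this read-out can resolve. This comparison rests on a single structural difference: the fact that compounds 2 and 3 differ only in the configuration as drawn. Compounds 1 and 2 differed in both the group and the configuration, whereas the new compound isolates cyano in place of bromo on an aromatic carbon, giving a 1.9-fold higher number from compound 1 to compound 3 (0.28 log units; within the scatter), so that exchange cannot be resolved here either.

The compounds shown leave open whether a different group on this aromatic carbon, such as an amine, a carboxylic acid or a methoxy group, would move the number beyond the scatter. They also leave open whether inverting both stereocentres would read the same with bromo in place of cyano.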